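The source may hold more compounds than are shown below. What is called first, only, known or untested is meant among the compounds shown, and "the series" means these compounds.

Of the compounds shown here, three have so far been measured in a functional assay on cells for agonist activity at C-X-C chemokine receptor type 4 (Homo sapiens), read by fluorescence and calcium flux, with a stated time of 90 s; on this read-out lower numbers stand for an effect already at smaller amounts and higher numbers for an effect only at larger amounts of compound. Compound 1 `c1ccc(CN(CCCCN(C[C@H]2Cc3ccccc3CN2)[C@H]2CCCc3cccnc32)Cc2ccccn2)nc1` gives > 30000 nM, a limit rather than a number. Compound 2 `c1ccc(CNCCCCN(C[C@H]2Cc3ccccc3CN2)[C@H]2CCCc3cccnc32)cc1` gives > 30000 nM, again a limit. Compound 3 `c1ccc2c(c1)CN[C@@H](CN(CCCCNCC1CCNCC1)[C@H]1CCCc3cccnc31)C2` gives > 30000 nM, also a limit. Among the measured compounds shown here, the one change between neighbours, a step that the two limits leave unreadable from compound 2 to compound 3, therefore cannot be sized. Every value shown sits at the limit of > 30000 nM in this assay, at which 3 of the 3 values shown sit. Compound 4 `c1ccc2c(c1)CN[C@@H](CN(CCCCNC1CCOCC1)[C@H]1CCCc3cccnc31)C2` differs from compound 3 by oxan-4-yl in place of (piperidin-4-yl)methyl on an amine nitrogen. For the measured compounds named here, no measured step bears directly on this change, and the single step measured was unreadable. Compound 4 is therefore expected to remain at the limit, with a step that the limit leaves unreadable from compound 3 to compound 4 as the estimated step, without a direction. The estimate for compound 4 in this assay is 50000 nM, in the range 10000 nM to 200000 nM.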

Compound 4, half-maximal effective concentration: > 30000 nM
Compound 4 gave a limit, no number; the forecaster's own chance of this, stated with the estimate: 85%; the middle value lies beyond the limit too.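

Among the compounds shown here, compound 4 sits at a limit, as do compound 2 and compound 3, so no step among them can be read: the limit of > 30000 nM in this assay, at which 4 of the 4 values shown sit.
As far as these compounds go, whether any change to the shared core gives a number in this assay remains open.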